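Cytotoxicity notes: oxazolyl in place of methoxy

The source may report more compounds than this note shows. Statements on the series, on what has been measured and on what is new or still open speak of the compounds shown alone.

Measured so far in an ADME assay on PC-3 cells (Homo sapiens) for cytotoxicity, read by WST assay, tested at 100 uM; a higher number here means more inhibition at the concentration tested (going by the name of the read-out), a lower number less inhibition:
compound 1 `CSc1cccc(NC(=O)C2CCCN(C(=O)c3cc(C(F)(F)F)cc(C(F)(F)F)c3)C2)c1` gives 0%;
compound 2 `COc1cccc(NC(=O)C2CCCN(C(=O)c3cc(C(F)(F)F)cc(C(F)(F)F)c3)C2)c1` gives 0%.

Compound 2 stands level with compound 1 in this assay, the step of no change at the digits printed from compound 1 to compound 2 (within the scatter) lying within the scatter. Compound 3 `O=C(Nc1cccc(-c2cnco2)c1)C1CCCN(C(=O)c2cc(C(F)(F)F)cc(C(F)(F)F)c2)C1` differs from compound 2 by 1,3-oxazol-5-yl in place of methoxy on an aromatic carbon. For the measured compounds named here, the only measured step that bears on a change at this aromatic carbon is the one from compound 1 to compound 2, and it showed no change, although it swapped a smaller group. With both measured compounds showing no inhibition, no step beyond the scatter is expected for compound 3 in this assay: no change at the digits printed from compound 2 to compound 3 (within the scatter). Compound 3 is therefore estimated at 0%, within -10% to 15%.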

Compound 3, a percentage reported as inhibition, at one concentration (the size of the read-out at that concentration, not a potency): 9%
The estimate for compound 3 lay 9 percentage points below the measured number; the measured number falls inside the stated range.
By their numbers in this assay, from the lowest: compounds 1, 2 and 3 (each within the scatter of the next).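

Placing 1,3-oxazol-5-yl on this aromatic carbon gives a number 9 percentage points higher from compound 2 to compound 3 (within the scatter) and a number 9 percentage points higher from compound 1 to compound 3 (within the scatter) in this assay. The position thus takes an aromatic ring as well as methoxy or methylsulfanyl, with no step beyond the scatter at the concentration tested. Nothing at hand offers an explanation for these readings.

Still open, going by these compounds, is whether an amine or a carboxylic acid on this carbon would give a step beyond the scatter. Also open, on these data alone, is whether changes elsewhere on the shared core would move this read-out.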